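Indole attachment isomers on a shared trimethoxyphenyl core

The compounds below may be only part of what the source reports. "The series", "measured", "known", "first", "only" and "open" are said of these compounds alone.

Measured in a functional assay on A549 cells (Homo sapiens) for inhibition, read by CCK-8 assay, with a stated time of 48 h; on this read-out lower numbers stand for stronger inhibition and higher numbers for weaker inhibition:
compound 1 `COc1ccc(-c2cc3nccc(-c4cc(OC)c(OC)c(OC)c4)n3n2)cc1N` gives 138 nM
compound 2 `COc1ccc(-c2cc3nccc(-c4cc(OC)c(OC)c(OC)c4)n3n2)cc1F` gives 545 nM
compound 3 `COc1cc(-c2ccnc3cc(-c4ccc5ccn(C)c5c4)nn23)cc(OC)c1OC` gives 829 nM

Compound 3 holds the highest number of the three. Its gap to compound 2 lies within the scatter; its gap to compound 1, a 6.0-fold higher number from compound 1 to compound 3 (0.78 log units; beyond the scatter), lies beyond it. Compound 4 `COc1cc(-c2ccnc3cc(-c4ccc5c(ccn5C)c4)nn23)cc(OC)c1OC` differs from compound 3 by 1-methyl-1H-indol-5-yl in place of 1-methyl-1H-indol-6-yl on an aromatic carbon. Going by the values given here, the measured steps do not bear on this change: a 3.9-fold higher number from compound 1 to compound 2 (0.60 log units; beyond the scatter) and a 1.5-fold higher number from compound 2 to compound 3 (0.18 log units; within the scatter) concern other groups, and no measured pair moves the indolyl between its attachment points. In this assay compound 4 is therefore expected to give a number close to that of compound 3, with no step beyond the scatter. The estimate for compound 4 is 800 nM, range 300 nM to 2500 nM. The expected step is a 1.0-fold lower number from compound 3 to compound 4 (0.02 log units; within the scatter).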

Compound 4, half-maximal inhibitory concentration: 15 nM
Beside the measured number, compound 4's estimate is 53-fold (1.73 log units) above it; the whole stated range lies above it.
By their numbers in this assay, from the lowest: compound 4; then compound 1; then compounds 2 and 3 (each within the scatter of the next).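

In this assay the attachment point of the indolyl at this place carries a large effect: the same atoms, joined differently, give a 55-fold lower number from compound 3 to compound 4 (1.74 log units; beyond the scatter). The 1-methyl-1H-indol-5-yl group also goes beyond both substituted phenyl groups, with a 36-fold lower number from compound 2 to compound 4 (1.56 log units; beyond the scatter) and a 9.2-fold lower number from compound 1 to compound 4 (0.96 log units; beyond the scatter), so the indolyl is not tied to a weak result as compound 3 alone suggested. No data here account for the shift. Open, from the compounds shown here alone, is how 1H-indol-5-yl or 1-methyl-1H-indol-4-yl would compare with 1-methyl-1H-indol-5-yl at this place.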